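A few compounds are considered here, and "the series" means these few. Any claim that something is new, unique, unknown or untested is made for them only; others in the source may bear on it.

Measured so far in a functional assay on L132 cells (Homo sapiens) for cytotoxicity, read by MTT assay, with a stated time of 72 h; a lower number here means that less compound is needed, a higher number that more compound is needed for the effect:
- compound 1, `O=C1/C(=C\c2ccc(O)cc2)c2ccccc2N1c1c(Cl)cccc1Cl`: 30 ug/mL
- compound 2, `COc1ccc(/C=C2\C(=O)N(c3c(Cl)cccc3Cl)c3ccccc32)cc1OC`: a limit, > 100 ug/mL

Among the compounds with values here, compound 1 holds the only number reported in this assay. Compound 2 gives no number in this assay, only the limit > 100 ug/mL. The single limit shown, (the limit of > 100 ug/mL in this assay, at which 1 of the 2 values shown sits), is all there is beside compound 1, so no step between measured compounds can be laid out and no size of effect for any change is known from the series itself.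

Compound 3, `CN(C)c1ccc(/C=C2\C(=O)N(c3c(Cl)cccc3Cl)c3ccccc32)cc1`, is the next compound in line. It differs from compound 1 in one place: dimethylamino in place of hydroxy on an aromatic carbon

Within the data shown here, with no measured step to lean on, the expectation for this change rests on compound 1 alone, whose value in this assay is 30 ug/mL. The step expected from compound 1 to compound 3, a 1.3-fold higher number from compound 1 to compound 3 (0.12 log units; within the scatter), is estimated to be small, within or close to the usual scatter, tending if anything toward more compound needed. Compound 3 is therefore estimated to give 40 ug/mL in this assay, with a range from 12 ug/mL to 120 ug/mL, and a real chance that only a limit is reported.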

Compound 3, concentration for half-maximal effect: > 100 ug/mL
Compound 3: a limit, no number (the forecaster's own chance of this, stated with the estimate: 30%); middle value at least 2.5-fold (0.39 log units) from the limit.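

In this assay, within the data shown here, the change from 4-hydroxyphenyl to 4-(dimethylamino)phenyl gives the first one-place comparison, with an at least 3.3-fold higher number from compound 1 to compound 3 (0.52 log units; beyond the scatter). At this position, para to a large group, the hydroxy of compound 1 therefore cannot be exchanged for dimethylamino without a shift beyond the scatter toward more compound needed. Compound 3 gives only a limit, > 100 ug/mL, so the step fixes a direction and a minimum size but no end point, and limits now make up most of the record: the limit of > 100 ug/mL in this assay, at which 2 of the 3 values shown sit.

Among these compounds, compound 1 remains the only compound with a number, and this single pair cannot separate the loss of the hydrogen-bond donor of hydroxy from the arrival of the larger dimethylamino. Going by these compounds, how a primary amine, a single methoxy or a carboxylic acid at the same place would read in this assay stays open, and so does whether any group here gives a lower number than compound 1.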